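A few compounds are considered here, and "the series" means these few. Any claim that something is new, unique, unknown or untested is made for them only; others in the source may bear on it.

Working notes on the series in a functional assay for inhibition, tested at 60 ug/mL; on this read-out lower numbers stand for a weaker effect and higher numbers for a stronger effect at the one concentration tested. Compound 1 `COc1cc(-c2cc(-c3cc(C(C)C)c(O)cc3C)[nH]c(=O)c2C#N)cc(OC)c1OC` gives 71%. Compound 3 `Cc1cc(O)c(C(C)C)cc1-c1cc(-c2cccs2)c(C#N)c(=O)[nH]1` gives 54.3%. Compound 2 `COc1cccc(-c2cc(-c3cc(C(C)C)c(O)cc3C)[nH]c(=O)c2C#N)c1` gives 38%, the lowest of the three numbers; compound 3 stands nearest and compound 1 furthest, both gaps beyond the scatter. Among the measured compounds shown here, the only measured step that changes one place is a number 16.3 percentage points higher from compound 2 to compound 3 (beyond the scatter), thiophen-2-yl in place of 3-methoxyphenyl on an aromatic carbon.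

Compound 4 `COc1ccc(-c2cc(-c3cc(C(C)C)c(O)cc3C)[nH]c(=O)c2C#N)c(OC)c1` is not yet measured. It differs from compound 2 as follows: 2,4-dimethoxyphenyl in place of 3-methoxyphenyl on an aromatic carbon. For the measured compounds named here, no measured step swaps one methoxy-bearing phenyl for another at this position, so the step from compound 2 to compound 3 bears on it only loosely: a change of the group on this aromatic carbon shifted this assay by a modest amount and upward. For the direction, compound 1 gives 71%, while compound 2 gives 38%; the pair differs in more than one place, so only the two values can be compared. On that basis a modest upward step is expected for compound 4, a number 14 percentage points higher from compound 2 to compound 4 (beyond the scatter), with wide uncertainty. The estimate for compound 4 is 52%, expected to fall between 32% and 72%.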

Compound 4, a percentage reported as inhibition, at one concentration (the size of the read-out at that concentration, not a potency): 48.5%
Beside the measured number, compound 4's estimate is 3.5 percentage points above it; the range from low to high includes it.
By their numbers in this assay, from the lowest: compound 2; then compounds 4 and 3 (each within the scatter of the next); then compound 1.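

Among the compounds shown, this is the only step that exchanges one methoxy-bearing phenyl for another on the aromatic carbon opposite the ring nitrogen, and in this assay it gives a number 10.5 percentage points higher from compound 2 to compound 4 (beyond the scatter), so the read-out responds to the methoxy pattern on the phenyl and not only to replacing the phenyl with thiophen-2-yl. The other new step, a number 5.8 percentage points lower from compound 3 to compound 4 (within the scatter), leaves 2,4-dimethoxyphenyl and thiophen-2-yl unresolved in this assay, so a six-membered carbon ring and the thiophene can give readings that cannot be told apart at this position. No measurement available here bears on why either step has this size.

Open is whether the gain follows the methoxy groups themselves or their placement on the phenyl, as no compound shown carries a single methoxy group at another ring carbon. Also open, as far as these compounds go, is how this aromatic carbon responds to a phenyl carrying an amine or a carboxylic acid, or to an unsubstituted phenyl, and a single-concentration percentage says nothing about potency in any of these cases.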